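Swapping a fluorine for a methylpyrazole on the shared core

The compounds below may be only part of what the source reports. "The series", "measured", "known", "first", "only" and "open" are said of these compounds alone.

Measured compounds:
- compound 1, `COc1cc(-c2ccnc3cc(-c4ccc(F)cc4)nn23)cc(OC)c1OC`: 1280 nM
- compound 2, `COc1ccc(-c2cc3nccc(-c4cc(OC)c(OC)c(OC)c4)n3n2)cc1F`: 183 nM

Both were tested in a functional assay on MCF7 cells (Homo sapiens) for inhibition, read by CCK-8 assay, with a stated time of 48 h; on this read-out lower numbers stand for stronger inhibition and higher numbers for weaker inhibition. Compound 1 stands at the highest number of the two, and its nearest neighbour is compound 2, reached by a 7.0-fold lower number from compound 1 to compound 2 (0.84 log units; beyond the scatter), a change in which a 3-fluoro-4-methoxyphenyl group replaces a 4-fluorophenyl group on an aromatic carbon.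

The next compound, compound 3, has the structure `COc1cc(-c2ccnc3cc(-c4ccc(-c5cnn(C)c5)cc4)nn23)cc(OC)c1OC`. Compared with compound 1 it differs in one place: 1-methyl-1H-pyrazol-4-yl in place of fluoro on an aromatic carbon. Among the compounds with values here, the only measured step also modifies this same outer ring of the core, and it lowered the number from compound 1 to compound 2, but it exchanged a fluorine for a different small substituent rather than adding a five-membered aromatic ring, so it does not speak directly to this change. On that thin basis a small lowering of the number, or none beyond the scatter, is expected, and a 1.8-fold lower number from compound 1 to compound 3 (0.26 log units; within the scatter) is the estimated step. Compound 3 is expected to give about 700 nM, within a range from 200 nM to 2500 nM.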

Compound 3, half-maximal inhibitory concentration: 274 nM
The estimate for compound 3 lay 2.6-fold (0.41 log units) above the measured number; the measured number falls inside the stated range.
By their numbers in this assay, from the lowest: compounds 2 and 3 (each within the scatter of the next); then compound 1.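

In this assay, the place on the six-membered aromatic ring, para to a large group, proves able to take far more than a single fluoro atom: putting 1-methyl-1H-pyrazol-4-yl there gives a 4.7-fold lower number from compound 1 to compound 3 (0.67 log units; beyond the scatter), a step beyond the scatter. The earlier step, a 7.0-fold lower number from compound 1 to compound 2 (0.84 log units; beyond the scatter), exchanged one substituted phenyl group for another, so it could not show that a whole extra five-membered aromatic ring is compatible with a lower number at this place. No measurement at hand explains why the number falls with this change.

The compounds shown do not separate the contributions of the new ring, its two nitrogen atoms and its methyl group, so a pyrazole without the methyl, a plain phenyl ring or a pyridine at the same place would be needed to tell which part matters. Nor do they show how far this place accepts groups of other kinds, such as a morpholine, a carboxylic acid or a longer alkyl chain.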